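A few compounds are considered here, and "the series" means these few. Any claim that something is new, unique, unknown or untested is made for them only; others in the source may bear on it.

Measured compounds:
- Compound 1, `CNc1nc(C)c(-c2nc3ccccc3s2)c(N[C@@H]2C[C@H](CO)[C@@H](O)[C@H]2O)n1`; in an ADME assay on cells (Homo sapiens) for cytotoxicity, read by polymerase chain reaction, with a stated time of 3 days (on this read-out lower numbers stand for higher toxicity in this test and higher numbers for lower toxicity in this test), compound 1 gives only a limit, > 25000 nM.
- Compound 2, `CCNc1nc(C)c(-c2nc3ccccc3s2)c(N[C@@H]2C[C@H](CO)[C@@H](O)[C@H]2O)n1`; in this assay compound 2 gives 12000 nM.
- Compound 3, `Cc1nc(N(C)C)nc(N[C@@H]2C[C@H](CO)[C@@H](O)[C@H]2O)c1-c1nc2ccccc2s1`; in this assay compound 3 gives 18000 nM.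

Compound 3 stands at the top of the two numbers, with compound 2 nearest: a 1.5-fold higher number from compound 2 to compound 3 (0.18 log units; within the scatter). The limit of compound 1 is a limit and not a number; (the limit of > 25000 nM in this assay, at which 1 of the 3 values shown sits).

Compound 4 is `COCCNc1nc(C)c(-c2nc3ccccc3s2)c(N[C@@H]2C[C@H](CO)[C@@H](O)[C@H]2O)n1`. It differs from compound 3 in one place: (2-methoxyethyl)amino in place of dimethylamino on an aromatic carbon.

Among the compounds with values here, three measured steps bear on this. The step of an at least 2.0-fold lower number from compound 1 to compound 2 (0.31 log units; beyond the scatter) shows that lengthening the chain on the nitrogen on the aromatic ring lowered the number. The step of an at least 1.3-fold lower number from compound 1 to compound 3 (0.14 log units; that floor lies within the scatter) shows a change on the same nitrogen of uncertain size. The step of a 1.5-fold higher number from compound 2 to compound 3 (0.18 log units; within the scatter), which exchanges a dimethylamino for an ethylamino-type group, lies within the scatter. A further lengthening of the chain, as in compound 4, is therefore expected to give at most a modest lowering in this assay, or none beyond the scatter.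

For compound 4 the expected value in this assay is 11000 nM, with a range from 4500 nM to 25000 nM, which means an expected step of a 1.6-fold lower number from compound 3 to compound 4 (0.21 log units; within the scatter).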

Compound 4, half-maximal cytotoxic concentration: 21000 nM
Compound 4: the middle estimate sits 1.9-fold (0.28 log units) below what was measured; the measured number falls inside the stated range.
By their numbers in this assay, from the lowest: compounds 2, 3 and 4 (each within the scatter of the next). At a limit, above all of these: compound 1.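

In this assay, (2-methoxyethyl)amino in place of dimethylamino on the aromatic carbon between two ring nitrogen atoms gives a 1.2-fold higher number from compound 3 to compound 4 (0.07 log units; within the scatter). Adding methoxy to the saturated chain gives the same picture, with a 1.8-fold higher number from compound 2 to compound 4 (0.24 log units; within the scatter), so this position now accepts a chain bearing an oxygen and a hydrogen-bond donor with no change beyond the scatter, and compounds 2, 3 and 4 cannot be separated in this assay. Compound 1 gives only a limit: the limit of > 25000 nM in this assay, at which 1 of the 4 values shown sits. The step that rests on this limit is an at least 1.1-fold lower number from compound 1 to compound 4 (0.07 log units; that floor lies within the scatter).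

The only step beyond the scatter at this position remains an at least 2.0-fold lower number from compound 1 to compound 2 (0.31 log units; beyond the scatter), and it rests on that limit, so the effect of chain length on the nitrogen stays unsettled across the compounds shown. From the compounds shown here alone, it also remains open whether a carboxylic acid at the end of the chain, a terminal dimethylamino on the chain, or a morpholine ring in place of the open chain would move the number in this assay beyond the scatter.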